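The source may hold more compounds than are shown below. What is called first, only, known or untested is meant among the compounds shown, and "the series" means these compounds.

In a functional assay on HeLa cells (Homo sapiens) for antiproliferative activity, read by MTT assay, with a stated time of 48 h (on this read-out lower numbers stand for stronger inhibition of growth and higher numbers for weaker inhibition of growth), compound 1 (`COC(=O)N1N=C(c2cccc(OC)c2)CC1c1cc(OC)c(OC)c(OC)c1`) gives 1530 nM. Compound 2 (`CCOC(=O)N1N=C(c2cccc(OC)c2)CC1c1cc(OC)c(OC)c(OC)c1`) gives 4110 nM, the higher of the two numbers, which makes it the weaker growth inhibitor of this pair. Compound 3 (`CCCOC(=O)N1N=C(c2cccc(OC)c2)CC1c1cc(OC)c(OC)c(OC)c1`) has yet to be measured. Its difference from compound 2 is methyl in place of hydrogen on a saturated chain carbon, two bonds along the chain from an oxygen next to a carbonyl group, so that ethoxy becomes propoxy.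

For the measured compounds named here, only one measured step bears on this change, a similar lengthening of the same chain, which gave a 2.7-fold higher number from compound 1 to compound 2 (0.43 log units; beyond the scatter). That step is modest, and a single step cannot show whether the trend carries on with a longer chain. A further rise in this assay of similar or somewhat smaller size is therefore expected, pointing towards weaker inhibition of growth, though a result close to compound 2 would not be surprising. The expected change is a 1.6-fold higher number from compound 2 to compound 3 (0.20 log units; within the scatter). For compound 3 the estimated value is 6500 nM, with an expected range of 2800 nM to 15000 nM.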

Compound 3, concentration for 50% growth inhibition: > 10000 nM
Compound 3: a limit, no number; the forecaster's own chance of this, stated with the estimate: 5%; middle value at least 1.5-fold (0.18 log units) from the limit.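

In this assay compound 3 gives a limit of the assay and not a number: the limit of > 10000 nM in this assay, at which 1 of the 3 values shown sits. Even so, the change from ethoxy to propoxy gives an at least 2.4-fold higher number from compound 2 to compound 3 (0.38 log units; beyond the scatter), so this second lengthening of the chain, like the first, goes beyond the scatter and towards weaker inhibition of growth, which a single step could not show. Taken together, the two changes give an at least 6.5-fold higher number from compound 1 to compound 3 (0.81 log units; beyond the scatter), leaving compound 1, with the shortest chain, as the strongest growth inhibitor of the three, and no compound shown goes against this rise with chain length.

Going by these compounds, since compound 3 is a limit, how far its true value lies from those of compound 1 and compound 2 stays unknown, and so does whether the second step is larger or smaller than the first. The compounds shown also leave open whether a longer chain such as butyl, a branched chain such as isopropyl, or a chain ending in an amine or a carboxylic acid would follow the same trend at this place.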